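Swapping the aryl group on a piperazine for a pyrimidine

The compounds below may be only part of what the source reports. "The series", "measured", "known", "first", "only" and "open" are said of these compounds alone.

Three compounds share one core, a diaminoquinazoline joined through a dithiocarbamate to a six-membered ring with two nitrogens, and differ only in the aromatic group carried by the ring nitrogen. Compound 1 `Cc1ccc(N2CCN(C(=S)SCc3ccc4nc(N)nc(N)c4c3)CC2)cc1` gives 2480 nM in a functional assay on MCF7 cells (Homo sapiens) for antiproliferative activity, read by MTT assay, with a stated time of 72 h; a higher number here means a weaker inhibitor, a lower number a stronger inhibitor. Compound 2 `Cc1ccc(N2CCN(C(=S)SCc3ccc4nc(N)nc(N)c4c3)CC2)c(C)c1` gives 3120 nM in this assay. Compound 3 `Nc1nc(N)c2cc(CSC(=S)N3CCN(c4ccc(Cl)c(Cl)c4)CC3)ccc2n1` gives 2370 nM in this assay, standing beside compound 1 and compound 2 with no gap beyond the scatter: a 1.0-fold lower number from compound 1 to compound 3 (0.02 log units; within the scatter) and a 1.3-fold lower number from compound 2 to compound 3 (0.12 log units; within the scatter).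

Compound 4 `Nc1nc(N)c2cc(CSC(=S)N3CCN(c4ncccn4)CC3)ccc2n1` differs from compound 3 at that same ring nitrogen: pyrimidin-2-yl in place of 3,4-dichlorophenyl on an amine nitrogen in a ring. The two measured steps that change the group at this position, from compound 1 to compound 3 and from compound 2 to compound 3, both stayed within the scatter, so the data offer no sign that this position moves the number. The entering pyrimidin-2-yl, with its 2 hydrogen-bond acceptors, is unlike any group already measured, which widens the uncertainty. Compound 4 is therefore expected to show no step beyond the scatter, a 1.1-fold higher number from compound 3 to compound 4 (0.04 log units; within the scatter), with an estimated value of 2600 nM and a range from 1000 nM to 7000 nM in this assay.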

Compound 4, half-maximal inhibitory concentration: 4190 nM
The estimate for compound 4 lay 1.6-fold (0.21 log units) below the measured number; the measured number falls inside the stated range.
By their numbers in this assay, from the lowest: compounds 3, 1, 2 and 4 (each within the scatter of the next).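

In this assay, within the data shown here, pyrimidin-2-yl is the first group on this ring nitrogen to have hetero atoms in its aromatic ring and hydrogen-bond acceptors, yet every step to it stays within the scatter: a 1.8-fold higher number from compound 3 to compound 4 (0.25 log units; within the scatter), a 1.3-fold higher number from compound 2 to compound 4 (0.13 log units; within the scatter) and a 1.7-fold higher number from compound 1 to compound 4 (0.23 log units; within the scatter). The earlier compounds shown here varied only carbon-only aromatic rings, so they could not show that this much larger change in the ring also produces no step beyond the scatter. No measurement here bears on what lies behind the sizes of these steps.

Still open, on these data alone, is whether the number would stay within the scatter with a group that is not aromatic on this ring nitrogen, such as a cyclohexyl ring or a short chain ending in an amine. A carboxylic acid carried on the aromatic ring is equally untested among the compounds shown.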